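The compounds below may be only part of what the source reports. "The series", "measured", "known", "first", "only" and "open" are said of these compounds alone.

Measured so far:
Compound 1, `N/C(=N\NC(=S)N1CCOCC1)c1ccccn1`, gives 14% in a functional assay on A-375 cells (Homo sapiens) for cytotoxicity, read by MTT assay, with a stated time of 72 h, tested at 100 uM; a higher number here means more inhibition of growth at the concentration tested, a lower number less inhibition of growth.
Compound 2, `N/C(=N\NC(=S)N1CCCCC1)c1ccccn1`, gives 88.5% in this assay.

Compound 2 stands highest of the two numbers; its nearest neighbour is compound 1, and the step of a number 74.5 percentage points higher from compound 1 to compound 2 (beyond the scatter) is the only one measured. Compound 3, `N/C(=N\NC(=S)N1CCCC1)c1ccccn1`, differs from compound 2 by pyrrolidin-1-yl in place of piperidin-1-yl on a thiocarbonyl carbon. Going by the values given here, the one measured step concerns the exchange of morpholin-4-yl for piperidin-1-yl at the same thiocarbonyl carbon, and it was large; it says nothing direct about shortening the ring by one carbon while keeping a single hetero atom, so it bears on the present step only loosely. With no closer comparison, compound 3 is expected to stay nearer compound 2 than compound 1, with a step of a number 18.5 percentage points lower from compound 2 to compound 3 (beyond the scatter), which may well lie within the scatter. Compound 3 is therefore estimated at 70%, within a range of 35% to 92%.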

Compound 3, percent growth inhibition at one concentration: 87.8%
The estimate for compound 3 lay 17.8 percentage points below the measured number; the measured number falls inside the stated range.
By their numbers in this assay, from the lowest: compound 1; then compounds 3 and 2 (each within the scatter of the next).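

Within this pair, the ring on the thiocarbonyl carbon can be pyrrolidin-1-yl or piperidin-1-yl with no change beyond the scatter in this assay: the exchange gives a number 0.7 percentage points lower from compound 2 to compound 3 (within the scatter) for this change. Pyrrolidin-1-yl in place of morpholin-4-yl gives a number 73.8 percentage points higher from compound 1 to compound 3 (beyond the scatter) at the same carbon, so the large step no longer rests on piperidin-1-yl alone and now appears with two rings, leaving compound 1 apart from both. Nothing given here accounts for either step.

The compounds shown leave open whether azepan-1-yl or an open-chain dimethylamino group on the thiocarbonyl carbon would read like compound 2 and compound 3. They also leave open whether piperazin-1-yl, with a ring nitrogen where morpholin-4-yl has its oxygen, would read like compound 1 or like those two.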